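Trifluoromethoxy in Place of Acetyl on a Urea Series

The source may report more compounds than this note shows. Statements on the series, on what has been measured and on what is new or still open speak of the compounds shown alone.

Compound 1 `Cc1cc(NC(=O)Nc2ccc(N)cc2)c2ccccc2n1` reaches only the limit > 25000 nM in an ADME assay on Raji cells (Homo sapiens) for cytotoxicity, with a stated time of 72 h; a higher number here means that more compound is needed for the effect, a lower number that less compound is needed.
Compound 2 `CC(=O)c1ccc(NC(=O)Nc2cc(C)nc3ccccc23)cc1` reaches only the limit > 25000 nM in this assay.
Compound 3 `Cc1cc(NC(=O)Nc2cccc(C(C)(C)C)c2)c2ccccc2n1` reaches only the limit > 25000 nM in this assay.

Compound 2 stands at the limit of this assay, with no number of its own. The same holds for every other measured compound, since (the limit of > 25000 nM in this assay, at which 3 of the 3 values shown sit). Within the data shown here, the one measured step that reaches compound 2, a step that the two limits leave unreadable from compound 1 to compound 2, is therefore unreadable in size and direction.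

Compound 4 `Cc1cc(NC(=O)Nc2ccc(OC(F)(F)F)cc2)c2ccccc2n1` has not been measured in this assay. It differs from compound 2 in one place: trifluoromethoxy in place of acetyl on an aromatic carbon. No measured step bears on this change, and the only step into compound 2 gives no size, so nothing among the shown values points to a step beyond the scatter in either direction.

Compound 4 is expected to sit at 25000 nM, with a range from 10000 nM to 100000 nM. The step this estimate means, a number no higher from compound 2 to compound 4 (the limit leaves the size open), is expected to stay within the scatter, most likely as another limit.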

Compound 4, half-maximal effective concentration: 10000 nM
Compound 4: the middle estimate sits 2.5-fold (0.40 log units) above what was measured; low and high end bracket the measured number.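

With trifluoromethoxy on this aromatic carbon, para to a large group, compound 4 gives the only number rather than a limit among the compounds shown in this assay and so shows that this position can respond to the group placed on it. The change from acetyl gives an at least 2.5-fold lower number from compound 2 to compound 4 (0.39 log units; beyond the scatter) and the change from amino gives an at least 2.5-fold lower number from compound 1 to compound 4 (0.39 log units; beyond the scatter) in the same direction. Both steps give only a smallest size, since each starts from a limit: the limit of > 25000 nM in this assay, at which 3 of the 4 values shown sit.

The compounds shown leave open how large these steps really are. They also leave open whether another group on this carbon, such as chlorine, methoxy or trifluoromethyl, would give a like step, and whether trifluoromethoxy would do the same elsewhere on the ring.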